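Triazole series: benzylamine in place of arylamine

The source may report more compounds than this note shows. Statements on the series, on what has been measured and on what is new or still open speak of the compounds shown alone.

Measured so far:
compound 1 `COc1cccc(Nc2n[nH]c(-c3cccnc3Nc3cc(OC)cc(OC)c3)n2)c1` — 72%
compound 2 `COc1cc(Nc2n[nH]c(-c3cccnc3Nc3cc(OC)cc(OC)c3)n2)cc(OC)c1` — "not determined" (no result reported)

Compound 2 stands without a number in a functional assay on A-431 cells (Homo sapiens), tested at 0.1 uM; a higher number here means more inhibition at the concentration tested (going by the name of the read-out), a lower number less inhibition: for compound 2 the result is recorded as "not determined" (no result reported), so no single value can be placed against it. The only figure in hand in this assay comes from compound 1, which gives 72%.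

Compound 3 `COc1cccc(CNc2n[nH]c(-c3cccnc3Nc3cc(OC)cc(OC)c3)n2)c1` is the next step from compound 2. The change is 3-methoxybenzyl in place of 3,5-dimethoxyphenyl on a nitrogen on an aromatic ring. Going by the values given here, compound 2 carries no number, and no measured step can be given here; the step from compound 2 to compound 3 in this assay is expected to be of unknown size, and the direction is taken from the one point available, compound 1, where the aryl amine on the same nitrogen gives 72%. A drop beyond the scatter is expected for compound 3 on moving to the benzylamine.

For compound 3 in this assay the expected value is 45%, with a range from 15% to 75%.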

Compound 3, a percentage reported as inhibition, at one concentration (the size of the read-out at that concentration, not a potency): 71%
Estimate against measurement, compound 3: 26 percentage points below; the measured number falls inside the stated range.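

In this assay the series now gives a number 1 percentage points lower from compound 1 to compound 3 (within the scatter), with 3-methoxybenzyl in place of 3-methoxyphenyl on a nitrogen on an aromatic ring, so at this position the two groups cannot be told apart in this read-out, something a single value could not show. Compound 2 carries no number, so the step from it to compound 3 cannot be read, and the 3,5-dimethoxyphenyl group remains without a comparison here. No measurement at hand bears on the reason for this result.

On these data alone, whether the same holds for a longer chain on this nitrogen, such as 2-(3-methoxyphenyl)ethyl, or for a benzyl group carrying an amine or a carboxylic acid in place of the methoxy, stays open. A reading at one concentration also leaves open whether compound 1 and compound 3 would match across a full concentration range.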